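Sulfonyl quinoline series: aryl swap on the core

A few compounds are considered here, and "the series" means these few. Any claim that something is new, unique, unknown or untested is made for them only; others in the source may bear on it.

The series shares one core, with compound 1 `Cc1ccc(S(=O)(=O)c2cnc3cc(F)ccc3c2-c2ccc(F)cc2)cc1C`, compound 2 `O=S(=O)(c1cc(Cl)cc(Cl)c1)c1cnc2cc(F)ccc2c1-c1ccc(F)cc1` and compound 3 `COc1ccc(S(=O)(=O)c2cnc3cc(F)ccc3c2-c2ccc(F)cc2)cc1Cl` measured in an ADME assay on microsomes from liver (Homo sapiens) for metabolic stability, tested at 2.5 uM; a lower number here means slower removal, a higher number faster removal of the compound. Compound 1 gives 9.25 mL/min, compound 2 gives 0.18 mL/min and compound 3 gives 1.29 mL/min, which puts compound 3 second highest of the three, nearest to compound 2 and furthest from compound 1. The measured steps are a 51-fold lower number from compound 1 to compound 2 (1.71 log units; beyond the scatter), a 7.2-fold lower number from compound 1 to compound 3 (0.86 log units; beyond the scatter) and a 7.2-fold higher number from compound 2 to compound 3 (0.86 log units; beyond the scatter), all on the sulfonyl sulfur. Compound 4 `COc1ccc(S(=O)(=O)c2cnc3cc(F)ccc3c2-c2cccc(Cl)c2)cc1Cl` differs from compound 3 elsewhere: 3-chlorophenyl in place of 4-fluorophenyl on an aromatic carbon. No measured step touches that position, so nothing shown bears directly on it; a step within the scatter is expected, direction open. Compound 4 is therefore estimated at 1.3 mL/min in this assay, range 0.4 mL/min to 4 mL/min, a step of a 1.0-fold higher number from compound 3 to compound 4 (0.00 log units; within the scatter).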

Compound 4, intrinsic clearance in a liver preparation (reported as CLH), per the amount of preparation that the assay uses: 1.19 mL/min
Compound 4: middle estimate off by 1.1-fold (0.04 log units), on the high side, within the range that was stated.
By their numbers in this assay, from the lowest: compound 2; then compounds 4 and 3 (each within the scatter of the next); then compound 1.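

Among these compounds, the first measured step at this position, 3-chlorophenyl in place of 4-fluorophenyl, is a 1.1-fold lower number from compound 3 to compound 4 (0.04 log units; within the scatter) in this assay and lies within the scatter, whereas all steps on the sulfonyl sulfur lie beyond it. With 3-chloro-4-methoxyphenyl on the sulfonyl sulfur, this exchange of aryl groups leaves intrinsic clearance unresolved between the two compounds. No supporting data bear on the reason for this result. On these data alone, whether the exchange behaves alike with 3,5-dichlorophenyl or 3,4-dimethylphenyl on the sulfonyl sulfur remains open. So does the effect of an aryl group carrying an amine or a carboxylic acid at this position.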